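Replacing a cyclohexylsulfonyl group with naphthalen-1-yl

This account rests on a few compounds, and the source may have more. Where it says the series, first, only, none or still open, it means among the compounds named here.

Compound 1: `Cc1c(Cc2ccccc2S(=O)(=O)c2ccc(F)cc2)c2c(n1CC(=O)O)CCNC2=O` — 3.3 nM
Compound 2: `Cc1c(Cc2ccccc2S(=O)(=O)C2CCCCC2)c2c(n1CC(=O)O)CCNC2=O` — 28 nM

In a functional assay on CHO.K1 cells for antagonist activity at prostaglandin D2 receptor 2 (Homo sapiens), read by GTPgammaS binding, with a stated time of 1 h (on this read-out higher numbers stand for weaker inhibition and lower numbers for stronger inhibition), compound 2 gives the highest of the two numbers, weaker than compound 1 by an 8.5-fold higher number from compound 1 to compound 2 (0.93 log units; beyond the scatter). Compound 3, `Cc1c(Cc2ccccc2-c2cccc3ccccc23)c2c(n1CC(=O)O)CCNC2=O`, differs from compound 2 by naphthalen-1-yl in place of cyclohexylsulfonyl on an aromatic carbon. For the measured compounds named here, the only measured step swaps the group on the sulfonyl sulfur, so it bears on compound 3 only loosely: it shows that an aromatic ring there gave the stronger number, but no measured compound lacks the sulfonyl altogether. A step back toward compound 1 is therefore expected, with wide uncertainty. Compound 3 is estimated at 12 nM, likely between 2 nM and 120 nM, an expected change of a 2.3-fold lower number from compound 2 to compound 3 (0.37 log units; beyond the scatter).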

Compound 3, half-maximal inhibitory concentration: 480 nM
Compound 3: middle estimate off by 40-fold (1.60 log units), on the low side, and the stated range ends below it.
By their numbers in this assay, from the lowest: compound 1; then compound 2; then compound 3.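

Losing the sulfonyl link and placing naphthalen-1-yl directly on the aromatic carbon weakens inhibition far more than the one change on the sulfur did, with a 17-fold higher number from compound 2 to compound 3 (1.23 log units; beyond the scatter) and a 150-fold higher number from compound 1 to compound 3 (2.16 log units; beyond the scatter). An aromatic ring at this position therefore does not by itself give the strength of compound 1, and both compounds that keep the sulfonyl give lower numbers. Nothing measured here explains this loss. On these data alone, it remains open whether naphthalen-1-yl would fare better on a sulfonyl sulfur, and whether an amide or an ether oxygen could stand in for the sulfonyl.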